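The source may report more compounds than this note shows. Statements on the series, on what has been measured and on what is new or still open speak of the compounds shown alone.

In a physicochemical assay for solubility, in phosphate buffer (on this read-out lower numbers stand for lower solubility and higher numbers for higher solubility), compound 1 (`Cc1cc(N[C@H](CCCCN)C(=O)NO)cc(C)c1F`) gives > 5 ug/mL, which is a limit and not a number. Compound 2 (`Cc1cc(N[C@H](CCCCNCc2ccccc2F)C(=O)NO)cc(C)c1F`) gives > 5 ug/mL, also a limit. As far as these compounds go, compound 3 (`COc1ccc(CNCCCC[C@@H](Nc2cc(C)c(F)c(C)c2)C(=O)NO)cc1`) gives > 5 ug/mL, again a limit, so its exact place is unknown. Compound 4 (`Cc1cc(N[C@H](CCCCNCc2ccc(C(C)(C)C)cc2)C(=O)NO)cc(C)c1F`) carries tert-butyl in place of methoxy on an aromatic carbon, para to a large group: tert-butyl in place of methoxy on an aromatic carbon. The closest measured comparison is a step that the two limits leave unreadable from compound 2 to compound 3, which also exchanges an aromatic group. Two others bear on it: a step that the two limits leave unreadable from compound 1 to compound 2 and a step that the two limits leave unreadable from compound 1 to compound 3. Their sizes stay hidden because of the limit of > 5 ug/mL in this assay, at which 3 of the 3 values shown sit. With no readable size to draw on, no step beyond the scatter is expected in this assay, and no direction can be given. The expected change is a step that the limit leaves unreadable from compound 3 to compound 4. The estimate for compound 4 is 7 ug/mL, expected between 2 ug/mL and 30 ug/mL.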

Compound 4, solubility: > 5 ug/mL
Compound 4: only a limit was reported (the forecaster's own chance of this, stated with the estimate: 60%); the middle value lies beyond the limit too.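

No step from compound 2 or compound 3 to compound 4 can be read, because each value is a limit and not a number: the limit of > 5 ug/mL in this assay, at which 4 of the 4 values shown sit.

As far as these compounds go, the true sizes of any differences among compound 1, compound 2, compound 3 and compound 4 in this assay stay open.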